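Swapping Diethylamino for Chloro: What to Expect

This account rests on a few compounds, and the source may have more. Where it says the series, first, only, none or still open, it means among the compounds named here.

Of the compounds shown here, three built on one shared core have been tested in a functional assay on HT-29 cells (Homo sapiens) for antiproliferative activity, read by MTT assay, with a stated time of 24 h; a lower number here means a stronger inhibitor, a higher number a weaker inhibitor. Compound 1 `COc1cc(OC)c(OC)cc1/C=C/C(=O)c1ccc(OC)c2c1OC(C)(C)C=C2` reached only the limit of the assay, giving > 10000 nM; this is a limit rather than a number, and it is the point at which the limit of > 10000 nM in this assay, at which 1 of the 3 values shown sits, sits. Compound 3 `COc1ccc(C(=O)/C=C/c2cccc(C(F)(F)F)c2)c2c1C=CC(C)(C)O2` gives 9050 nM. Compound 2 `CCN(CC)c1ccc(/C=C/C(=O)c2ccc(OC)c3c2OC(C)(C)C=C3)cc1` gives 550 nM, the lowest of the two numbers available, and its nearest neighbour, compound 3, stands at a higher value by a gap beyond the usual scatter, so compound 2 is the stronger inhibitor of that pair.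

Compound 4 `COc1ccc(C(=O)/C=C/c2ccc(Cl)cc2)c2c1C=CC(C)(C)O2` has not yet been measured. It differs from compound 2 in a single place: chloro in place of diethylamino on an aromatic carbon. Within the data shown here, no pair of measured compounds differs by exactly this change, so the size of the step can only be expected, not read off. The measured compound that carries trifluoromethyl rather than diethylamino, compound 3, is clearly weaker than compound 2. Giving up the diethylamino group is therefore expected to cost potency. The step from compound 2 to compound 4 is expected to be a 9.1-fold higher number from compound 2 to compound 4 (0.96 log units; beyond the scatter), a loss beyond the scatter. Compound 4 is accordingly estimated at 5000 nM, with a likely range from 1500 nM to 15000 nM.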

Compound 4, half-maximal inhibitory concentration: > 10000 nM
Compound 4: only a limit was reported; the forecaster's own chance of this, stated with the estimate: 25%; middle value at least 2.0-fold (0.30 log units) from the limit.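

In this assay compound 4 gives > 10000 nM, which is a limit of the assay and not a number. Among these compounds, at this position, on an aromatic carbon para to a large group, diethylamino cannot be exchanged for chloro without a large loss: the change gives an at least 18-fold higher number from compound 2 to compound 4 (1.25 log units; beyond the scatter), and it is the first single change in this set whose effect can be read directly. From the compounds shown here alone, that step is only a minimum, and the full size of the loss stays unknown, because the reading for compound 4 stops at the limit of the assay: the limit of > 10000 nM in this assay, at which 2 of the 4 values shown sit.

The compounds shown leave open how much of the diethylamino group is needed at this position, and a plain amine, a dimethylamino group or a longer chain on the nitrogen, such as dipropylamino, would help separate the role of the nitrogen from that of its two ethyl chains. They also give no measured property of either group that could explain why compound 2 holds a number while compound 4 reaches only a limit.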